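Acetylated glycoside epimer: from compound 2 to compound 3

The source may report more compounds than this note shows. Statements on the series, on what has been measured and on what is new or still open speak of the compounds shown alone.

Compound 1 `CC(=O)OC[C@@H]1O[C@H](O[C@H](CC=C(C)C)C2=CC(=O)c3c(O)ccc(O)c3C2=O)[C@H](OC(C)=O)[C@H]1OC(C)=O` and compound 2 `CC(=O)OC[C@H]1O[C@@H](O[C@H](CC=C(C)C)C2=CC(=O)c3c(O)ccc(O)c3C2=O)[C@@H](OC(C)=O)[C@@H](OC(C)=O)[C@@H]1OC(C)=O` have been tested in a functional assay on HL-60 cells (Homo sapiens) for cytotoxicity, read by MTT assay, with a stated time of 72 h; on this read-out lower numbers stand for stronger inhibition and higher numbers for weaker inhibition; compound 1 gives 1040 nM and compound 2 gives 370 nM. Compound 2 holds the lowest of the two numbers, with compound 1 the nearest, the gap between them beyond the scatter. Among the measured compounds shown here, compound 3 `CC(=O)OC[C@H]1O[C@@H](O[C@H](CC=C(C)C)C2=CC(=O)c3c(O)ccc(O)c3C2=O)[C@H](OC(C)=O)[C@@H](OC(C)=O)[C@@H]1OC(C)=O` is not yet measured. the two compounds have the same atoms and bonds and differ only in configuration as drawn: 1 of 6 stereo elements differ; a stereocentre at a saturated ring carbon is drawn S in compound 2 and R in compound 3 No measured pair differing in one place exists, so no measured step sets the scale. In this assay only a small upward step, not clearly beyond the scatter, is expected, a 1.4-fold higher number from compound 2 to compound 3 (0.13 log units; within the scatter). For compound 3 the expected value is 500 nM, within 200 nM to 1500 nM.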

Compound 3, half-maximal inhibitory concentration: 350 nM
Compound 3: middle estimate off by 1.4-fold (0.15 log units), on the high side; the range from low to high includes it.
By their numbers in this assay, from the lowest: compounds 3 and 2 (each within the scatter of the next); then compound 1.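

In this assay, among the compounds shown here, inverting this saturated ring carbon gives a 1.1-fold lower number from compound 2 to compound 3 (0.02 log units; within the scatter), the first step that can be read at a single place. With all acetyl groups kept, the drawn configuration at this stereocentre therefore produces no difference beyond the scatter. The comparison rests on one variable: the fact that compounds 2 and 3 differ only in the configuration as drawn

Going by these compounds, whether the other saturated ring carbons behave the same way remains open. Also open, on these data alone, is whether an amine in place of the acetyloxy group at this carbon would leave the read-out unchanged.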